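The source may report more compounds than this note shows. Statements on the series, on what has been measured and on what is new or still open speak of the compounds shown alone.

Three measured compounds set the scene. In an assay on CHO cells for displacement of a labelled ligand from Glucagon receptor (Homo sapiens), read by scintillation proximity assay, with a stated time of 3 h (a lower number here means a stronger inhibitor, a higher number a weaker inhibitor), compound 1 `CCCOc1ccc(-c2cc(-c3cc(Cl)cc(Cl)c3)nn2Cc2ccc(C(=O)NCCC(=O)O)cc2)cc1Cl` gives 37.9 nM, compound 3 `CCOc1ccc2cc(-c3cc(-c4cc(Cl)cc(Cl)c4)nn3[C@@H](C)c3ccc(C(=O)NCCC(=O)O)cc3)ccc2c1` gives 8.1 nM, and compound 2 `COc1cc(Cl)cc(-c2cc(-c3ccc4cc(OC)ccc4c3)n([C@@H](C)c3ccc(C(=O)NCCC(=O)O)cc3)n2)c1` gives 14.8 nM. Among these three numbers compound 2 holds the second highest; its nearest neighbour is compound 3, a gap that lies within the usual scatter of this assay, and its furthest is compound 1, a gap that lies beyond it.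

The compound still to be measured is compound 4 `COc1ccc2cc(-c3cc(-c4cc(Cl)cc(C(F)(F)F)c4)nn3[C@@H](C)c3ccc(C(=O)NCCC(=O)O)cc3)ccc2c1`. It differs from compound 2 in a single place: trifluoromethyl in place of methoxy on an aromatic carbon. Among the compounds with values here, no pair of measured compounds is separated by this one change, and compound 1 and compound 3 differ from compound 2 elsewhere in the molecule as well, so the numbers do not fix the size of the step directly. What they do show is that this assay has placed all three measured compounds in a fairly narrow band, with no large swings among them.

The step is therefore expected to be small, a 1.5-fold lower number from compound 2 to compound 4 (0.17 log units; within the scatter), with a lean toward a somewhat lower number. Compound 4 is estimated at 10 nM, within a range from 4 nM to 30 nM.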

Compound 4, half-maximal inhibitory concentration: 1.9 nM
Compound 4: the middle estimate sits 5.3-fold (0.72 log units) above what was measured, outside the stated range (below it).
By their numbers in this assay, from the lowest: compound 4; then compounds 3 and 2 (each within the scatter of the next); then compound 1.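

In this assay, the change from 3-chloro-5-methoxyphenyl to 3-chloro-5-(trifluoromethyl)phenyl gives a 7.8-fold lower number from compound 2 to compound 4 (0.89 log units; beyond the scatter), the only single-place step shown here, and it shows that this position, meta to a chloro group, responds to the choice of group by more than the usual scatter. The earlier compounds shown here each differ from one another in more than one place, so they could not isolate this position, and their fairly narrow band gave no sign that one group there could carry a step of this size. Nothing measured here accounts for the step, which stands as an observation on this one pair.

Whether the step belongs to trifluoromethyl in particular stays open, as the compounds shown do not include a nitrile, a methyl group or a plain hydrogen at this position. Also open, from the compounds shown here alone, is whether trifluoromethyl in this place would give a like result on the core of compound 1, which differs from compound 2 elsewhere in the molecule as well.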